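Swapping chloro for fluoro on a growth-inhibiting anilide

This account rests on a few compounds, and the source may have more. Where it says the series, first, only, none or still open, it means among the compounds named here.

compound 1 (`O=C(CCCCC1CCSS1)NO`): "not active" (no number reported)
compound 2 (`O=C(CCCCC(S)CCS)Nc1ccccc1`): 8.37%
compound 3 (`O=C(CCCCC(S)CCS)Nc1ccc(Cl)cc1`): 22%

In a functional assay on NCI-H460 cells (Homo sapiens) for inhibition, read by MTT assay, with a stated time of 24 h, tested at 10 ug/mL (a lower number here means less inhibition of growth, a higher number more inhibition of growth at the concentration tested), compound 3 holds the higher of the two numbers available, while compound 1 gives no number at all. The next compound, compound 4 (`O=C(CCCCC(S)CCS)Nc1ccc(F)cc1`), has not been measured. It differs from compound 3 by a single swap, (fluoro in place of chloro on an aromatic carbon), which places fluoro in place of chloro on an aromatic carbon.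

Within the data shown here, only one measured step bears on this carbon: a number 13.6 percentage points higher from compound 2 to compound 3 (beyond the scatter), with chloro in place of hydrogen. Among the measured compounds shown here, that step is modest, and no measured compound carries fluoro, so it offers a scale rather than a direct answer. Compound 4 is expected to keep part of that gain, ending up somewhere around the span set by compound 2 at 8.37% and compound 3.

The expected change is a number 7 percentage points lower from compound 3 to compound 4 (within the scatter) and should be smaller than the measured step. Compound 4 is estimated at 15% with an expected range from 5% to 28% in this assay once it is tested.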

Compound 4, percent growth inhibition at one concentration: 18.1%
Compound 4: middle estimate off by 3.1 percentage points, on the low side, and the stated range covers the measured number.
By their numbers in this assay, from the lowest: compounds 2, 4 and 3 (each within the scatter of the next, the first and the last beyond it).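

In this assay, putting fluoro in place of chloro on this aromatic carbon gives a result that cannot be told apart from the chloro compound (a number 3.9 percentage points lower from compound 3 to compound 4 (within the scatter)). Fluoro in place of hydrogen also stays within the scatter (a number 9.7 percentage points higher from compound 2 to compound 4 (within the scatter)), whereas only chloro in place of hydrogen clears it (a number 13.6 percentage points higher from compound 2 to compound 3 (beyond the scatter)), so compound 4 cannot be separated from either neighbour, and the fluoro result sits unresolved between them. No measurement shown offers an explanation for these numbers.

Going by these compounds, whether bromo, methoxy or an amine at this same carbon would separate clearly from compound 2 remains open. So does the question of whether chloro or fluoro would give similar numbers on the other carbons of the ring.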